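The source may report more compounds than this note shows. Statements on the series, on what has been measured and on what is new or still open speak of the compounds shown alone.

The study concerns four compounds built on one shared core and examined in a physicochemical assay for solubility, at pH 2; a higher number here means a more soluble compound, a lower number a less soluble compound. Compound 1 `Cc1cccc2c(NCc3ccco3)nc(NC(C)C)nc12` carries a methyl group on the carbocyclic ring of its core. In this assay compound 1 gives >= 30000 nM, which is a limit of the assay and not a number.

Compound 2 `Cc1ccc2c(NCc3ccco3)nc(NC(C)C)nc2c1` has the same atoms as compound 1, joined differently; the difference between the two cores is not broken down here. In this assay compound 2 gives >= 30000 nM, again a limit rather than a number.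

Compound 3 `COc1cccc2c(NCc3ccco3)nc(NC(C)C)nc12` differs from compound 1 by methoxy in place of methyl on an aromatic carbon. In this assay compound 3 gives >= 30000 nM, which is a limit of the assay. The step that the two limits leave unreadable from compound 1 to compound 3 cannot be read because of the limit of >= 30000 nM in this assay, at which 3 of the 3 values shown sit.

Compound 4 `COc1ccc2c(NCc3ccco3)nc(NC(C)C)nc2c1` is not yet measured. It differs from compound 2 by methoxy in place of methyl on an aromatic carbon. Around the place the two cases differ: in compound 3 the group sits ortho to a fused ring and meta to a fused ring, while in compound 4 it sits meta to a fused ring and para to a fused ring, so this is the same kind of change rather than the same one. From compound 2 to compound 4 a step of a number no higher from compound 2 to compound 4 (the limit leaves the size open) is expected in this assay. That expectation rests on compound 2, which gives >= 30000 nM, a limit. It rests also on compound 3, which gives >= 30000 nM, likewise a limit. Compound 4 is therefore estimated at 30000 nM, ranging from 15000 nM to 60000 nM, most likely reported as a limit.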

Compound 4, solubility: >= 30000 nM
Compound 4 ended at the assay's limit (the forecaster's own chance of this, stated with the estimate: 85%); the middle value sits exactly at the limit.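

In this assay no new step can be read between compound 2 and compound 4, because both values are limits of the assay and not numbers: the limit of >= 30000 nM in this assay, at which 4 of the 4 values shown sit.

The compounds shown leave open the actual values of all four compounds, and with them whether methoxy in place of methyl on an aromatic carbon shifts the read-out in either case.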